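The source may hold more compounds than are shown below. What is called first, only, known or untested is meant among the compounds shown, and "the series" means these compounds.

Of the compounds shown here, three have been measured in an ADME assay on THP-1 cells (Homo sapiens) for cytotoxicity; a lower number here means that less compound is tolerated, a higher number that more compound is tolerated.
Compound 1 `c1ccc(-c2nc3ccccn3c2Nc2ccc3c(c2)OCCO3)nc1` gives 25600 nM.
Compound 2 `Clc1ccc2nc(-c3ccccn3)c(Nc3ccc4c(c3)OCCO4)n2c1` gives only a limit of the assay, > 50000 nM.
Compound 3 `c1ccc(-c2nc3ccccn3c2NCC2CC2)nc1` gives 19400 nM.

Compound 3 holds the lowest of the two numbers, and its nearest neighbour, compound 1, lies within the scatter of it. Compound 2 sits at the limit of > 50000 nM in this assay, at which 1 of the 3 values shown sits. The change to compound 4 `c1ccc(CNc2c(-c3ccccn3)nc3ccccn23)cc1` is phenyl in place of cyclopropyl on a saturated chain carbon bound to a nitrogen on an aromatic ring. Going by the values given here, the only measured step, an at least 1.9-fold higher number from compound 1 to compound 2 (0.29 log units; that floor lies within the scatter), concerns a different change, and its floor lies within the scatter, so no measured step bears directly on this exchange. With nothing pointing beyond the scatter in this assay, compound 4 is expected near compound 3, at 20000 nM, between 8000 nM and 50000 nM. The step this estimate implies is a 1.0-fold higher number from compound 3 to compound 4 (0.01 log units; within the scatter).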

Compound 4, half-maximal cytotoxic concentration: > 50000 nM
Compound 4 was reported as a limit; the forecaster's own chance of this, stated with the estimate: 15%; middle value at least 2.5-fold (0.39 log units) from the limit.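

The exchange of cyclopropyl for phenyl on a saturated chain carbon bound to a nitrogen on an aromatic ring gives an at least 2.5-fold higher number from compound 3 to compound 4 (0.41 log units; beyond the scatter) in this assay, the first step among these compounds whose floor lies beyond the scatter. It shows that this place, untouched by the earlier step, can move the number. Compound 4 is reported only as a limit: the limit of > 50000 nM in this assay, at which 2 of the 4 values shown sit.

The compounds shown leave open how far this step truly reaches. They also leave open whether cyclohexyl, a longer chain or an amine at this place would behave like phenyl or like cyclopropyl.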